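The source may hold more compounds than are shown below. What is called first, only, known or untested is meant among the compounds shown, and "the series" means these compounds.

Among the measured compounds shown here, compound 2 `COc1cc(C(=O)N/N=C/c2ccccc2F)cc(OC)c1OC` gives 81.8% in a functional assay on PC-3 cells (Homo sapiens) for antiproliferative activity, read by MTT assay, tested at 5 uM (on this read-out higher numbers stand for a stronger effect at the one concentration tested and lower numbers for a weaker effect), the higher of the two numbers measured; its only neighbour, compound 1 `COc1cc(C(=O)N/N=C/c2c(Cl)cccc2Cl)cc(OC)c1OC`, gives 52.1%. For the measured compounds named here, the one measured step, a number 29.7 percentage points higher from compound 1 to compound 2 (beyond the scatter), is the sole guide here. Compound 3 `COc1cc(C(=O)N/N=C/c2cc(Cl)cc(Cl)c2)cc(OC)c1OC` differs from compound 2 by 3,5-dichlorophenyl in place of 2-fluorophenyl on a carbon with a double bond to nitrogen. Two chlorines again replace the single fluorine, the reverse sense of that measured step, although as 3,5-dichlorophenyl rather than 2,6-dichlorophenyl, so a fall beyond the scatter is expected, perhaps smaller than the measured one. Compound 3 is therefore estimated at 60%, between 40% and 80%, a step of a number 21.8 percentage points lower from compound 2 to compound 3 (beyond the scatter).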

Compound 3, a percentage reported as inhibition, at one concentration (the size of the read-out at that concentration, not a potency): 46.3%
Beside the measured number, compound 3's estimate is 13.7 percentage points above it, within the range that was stated.
By their numbers in this assay, from the lowest: compounds 3 and 1 (each within the scatter of the next); then compound 2.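

In this assay the change to 3,5-dichlorophenyl gives a number 35.5 percentage points lower from compound 2 to compound 3 (beyond the scatter) and so shows that the 2-fluorophenyl compound also stands clear of a second dichlorophenyl compound. Replacing 2,6-dichlorophenyl with 3,5-dichlorophenyl gives a number 5.8 percentage points lower from compound 1 to compound 3 (within the scatter) and so shows no readable difference between these two chlorine patterns. Nothing available explains either result. The compounds shown leave open whether the fluorine itself or the lack of chlorine goes with the higher number. They also leave open how a plain phenyl, or a phenyl carrying an amine or a carboxylic acid, would compare on this carbon.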